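This account rests on a few compounds, and the source may have more. Where it says the series, first, only, none or still open, it means among the compounds named here.

Measured so far in an ADME assay on microsomes from liver (Mus musculus) for metabolic stability, read by LC-MS, using NADPH, with a stated time of 30 min, tested at 0.5 uM; a lower number here means slower removal, a higher number faster removal of the compound:
compound 1 `COc1ccc2nc(C)cc(OCC(=O)Nc3cccc(C)c3)c2c1` gives 18.1 mL.min-1.g-1
compound 2 `COc1ccc2nc(C)cc(OCC(=O)Nc3cc(C)ccc3C)c2c1` gives 50.2 mL.min-1.g-1

For the measured compounds named here, compound 2 stands highest of the two numbers; its nearest neighbour is compound 1, and the single step available, a 2.8-fold higher number from compound 1 to compound 2 (0.44 log units; beyond the scatter), rests on a methyl in place of hydrogen on an aromatic carbon.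

Compound 3 `COc1ccc2nc(C)cc(OCC(=O)Nc3cc(C)c(F)c(C)c3)c2c1` is not yet measured. It differs from compound 2 by 4-fluoro-3,5-dimethylphenyl in place of 2,5-dimethylphenyl on an amide-type nitrogen. Going by the values given here, no measured step covers this change directly. Among the compounds with values here, the one step on record, a 2.8-fold higher number from compound 1 to compound 2 (0.44 log units; beyond the scatter), was modest and concerned only a methyl entering on the ring that sits on the amide-type nitrogen; in compound 3 that ring carries fluorine together with methyl, a pattern without precedent among the measured compounds. With nothing in the series pointing to a large shift in either direction, a change within the scatter, or at most a modest one, is expected in this assay.

Compound 3 is therefore estimated at about 45 mL.min-1.g-1 in this assay, with a range of 18 mL.min-1.g-1 to 110 mL.min-1.g-1. The expected step is a 1.1-fold lower number from compound 2 to compound 3 (0.05 log units; within the scatter).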

Compound 3, intrinsic clearance in microsomes: 19.3 mL.min-1.g-1
Compound 3: the middle estimate sits 2.3-fold (0.37 log units) above what was measured; the measured number falls inside the stated range.
By their numbers in this assay, from the lowest: compounds 1 and 3 (each within the scatter of the next); then compound 2.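

On the ring held by the amide-type nitrogen, the number in this assay does not follow the count of methyl groups alone: compound 2 and compound 3 both carry two, yet 4-fluoro-3,5-dimethylphenyl in place of 2,5-dimethylphenyl gives a 2.6-fold lower number from compound 2 to compound 3 (0.42 log units; beyond the scatter), which takes back about as much as a 2.8-fold higher number from compound 1 to compound 2 (0.44 log units; beyond the scatter) added. Set against the 3-methylphenyl of compound 1, the same group gives a 1.1-fold higher number from compound 1 to compound 3 (0.03 log units; within the scatter), so a second methyl and a fluorine can enter at this place with no change beyond the scatter, and the higher number of compound 2 belongs to the 2,5-dimethylphenyl pattern rather than to every more heavily substituted ring among these three compounds. Nothing measured here bears on why these numbers differ.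

As far as these compounds go, the change from compound 2 to compound 3 alters the arrangement of the methyl groups and adds fluorine in a single step, so the share of each remains open. Also open, from the compounds shown here alone, is how the number responds at this place to a group of another kind, such as a methoxy, a nitrile or an amine, and whether the step carries over to changes on the shared core.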